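The compounds below may be only part of what the source reports. "The series", "measured", "known", "first", "only" and "open" are said of these compounds alone.

Compound 1 `NC[C@@H]1CCN(c2ccc3c(=O)c(C(=O)O)cn(Cc4ccc(-n5cccn5)cc4)c3c2)C1`: 61000 nM
Compound 2 `O=C(O)c1cn(Cc2ccc(-n3cccn3)cc2)c2cc(N3CC4CNCC4C3)c(F)cc2c1=O`: 173000 nM
Compound 3 `COc1c(N2CC[C@@H](CN)C2)c(F)cc2c(=O)c(C(=O)O)cn(Cc3ccc(-n4cccn4)cc3)c12`: > 200000 nM

All three were measured in an assay on isolated protein for inhibition of DNA topoisomerase 1 (Homo sapiens), with a stated time of 15 min; on this read-out lower numbers stand for stronger inhibition and higher numbers for weaker inhibition. Compound 3 gives no number of its own: its value is a limit of the assay, the single one of the three that sits at the limit of > 200000 nM in this assay, at which 1 of the 3 values shown sits. Compound 3 therefore stands at the weak edge of the measured set. Compound 4 `NC[C@@H]1CCN(c2cc3c(cc2F)c(=O)c(C(=O)O)cn3Cc2ccc(-n3cccn3)cc2)C1` differs from it in one place, (hydrogen in place of methoxy on an aromatic carbon). Among the measured compounds shown here, no measured pair covers this change, and with compound 3 known only as a limit, the size of the step cannot be read from the data. He nonetheless expects a move toward stronger inhibition in this assay, beyond the usual scatter. For compound 4 an inhibitory concentration of 120000 nM is expected, within 40000 nM to 300000 nM. That expectation corresponds to a step of an at least 1.6-fold lower number from compound 3 to compound 4 (0.22 log units; that floor lies within the scatter).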

Compound 4, half-maximal inhibitory concentration: 91600 nM
The estimate for compound 4 lay 1.3-fold (0.12 log units) above the measured number; the range from low to high includes it.
By their numbers in this assay, from the lowest: compounds 1, 4 and 2 (each within the scatter of the next, the first and the last beyond it). At a limit, above all of these: compound 3.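

In this assay, among the compounds shown here, hydrogen in place of methoxy gives an at least 2.1-fold lower number from compound 3 to compound 4 (0.33 log units; beyond the scatter), a step no earlier pair covered at this aromatic carbon, ortho to the 3-(aminomethyl)pyrrolidin-1-yl group. Compound 3 is only a limit, so this step has a floor but no full size: the limit of > 200000 nM in this assay, at which 1 of the 4 values shown sits. The other two steps, a 1.9-fold lower number from compound 2 to compound 4 (0.28 log units; within the scatter) with the group on the aromatic carbon exchanged and a 1.5-fold higher number from compound 1 to compound 4 (0.18 log units; within the scatter) with fluoro in place of hydrogen, stay within the scatter.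

As far as these compounds go, whether a hydroxy, an ethoxy or an amino group on that carbon would fall with compound 4 or with compound 3 stays open.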